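The source may report more compounds than this note shows. Statements on the series, on what has been measured and on what is new or still open speak of the compounds shown alone.

Working notes on the series.

Compound 1, `CC(C)(C)OC(=O)NCCCCCNC(=O)CN1CN(c2ccccc2)C2(CCN(C(=O)c3ccc(C(C)(C)C)cc3)CC2)C1=O`, is the weaker of the two measured compounds in an assay on HEK293 cells for displacement of a labelled ligand from NPC1-like intracellular cholesterol transporter 1 (Homo sapiens) (a lower number here means a stronger inhibitor, a higher number a weaker inhibitor), where compound 1 gives 13700 nM. Among the compounds with values here, the other measured compound, compound 2, `CC(C)(C)OC(=O)N1CCN(C(=O)CN2CN(c3ccccc3)C3(CCN(C(=O)c4ccc(C5CCCCC5)cc4)CC3)C2=O)CC1`, differs from compound 1 in more than one place, so no single step separates the pair; in this assay compound 2 gives 3500 nM, a number that stands beyond the scatter from that of compound 1.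

Compound 3, `CC(C)(C)c1ccc(C(=O)N2CCC3(CC2)C(=O)N(CC(=O)NCCCNS(C)(=O)=O)CN3c2ccccc2)cc1`, shares its core with compound 1 and differs from it in one place: methanesulfonamido in place of 2-((tert-butoxycarbonyl)amino)ethyl on a saturated chain carbon, three bonds along the chain from an amide-type nitrogen. Nothing in the measured data isolates the effect of such a change at this position, since compound 2 alters a different part of the molecule as well. The expectation for the step is therefore a small one, a 1.2-fold lower number from compound 1 to compound 3 (0.10 log units; within the scatter), in no firm direction and not clearly beyond the scatter. On that basis compound 3 is estimated to give 11000 nM in this assay, with a range from 3000 nM to 40000 nM, the width reflecting the absence of any measured step bearing on this change.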

Compound 3, half-maximal inhibitory concentration: 10400 nM
Beside the measured number, compound 3's estimate is 1.1-fold (0.02 log units) above it; measured number inside the range.
By their numbers in this assay, from the lowest: compound 2; then compounds 3 and 1 (each within the scatter of the next).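

In this assay, within the data shown here, this position now has its first step that can be read on its own: the change reads as a 1.3-fold lower number from compound 1 to compound 3 (0.12 log units; within the scatter) and is the only single-place comparison so far. Methanesulfonamido in place of 2-((tert-butoxycarbonyl)amino)ethyl, on a saturated chain carbon, three bonds along the chain from an amide-type nitrogen, therefore brings no change beyond the scatter, even though the entering group has fewer heavy atoms and brings in sulfur while losing the tert-butoxycarbonyl group. No measurement offered here explains why the two groups read alike.

One step at one position says little about this chain in general. From the compounds shown here alone, whether an amine, a carboxylic acid or a longer chain ending in methanesulfonamido at this place would move the number beyond the scatter stays open, and so does how much of the lower number of compound 2 belongs to each of the places in which it differs from compound 1.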